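The compounds below may be only part of what the source reports. "The series", "measured", "known", "first", "only" and "open" are said of these compounds alone.

Among the compounds with values here, compound 2 `O=C(Nc1ccc(Cl)cc1)Nc1nc(Sc2c[nH]c3ccccc23)cc(N2CCCC2)n1` gives 6410 nM in a functional assay on A549 cells (Homo sapiens) for inhibition, with a stated time of 72 h (a lower number here means a stronger inhibitor, a higher number a weaker inhibitor), the lowest of the three numbers measured so far. Compound 3 `O=C(Nc1ccc(Cl)cc1)Nc1nc(Sc2c[nH]c3ccccc23)cc(N2CCCCC2)n1` gives 18600 nM in this assay, and compound 1 `Cc1cc(Cl)ccc1NC(=O)Nc1nc(NC2CC2)cc(Sc2c[nH]c3ccccc23)n1` gives 31500 nM. Within the data shown here, the one change measured between close neighbours, a 2.9-fold higher number from compound 2 to compound 3 (0.46 log units; beyond the scatter), was modest and sits at a different part of the molecule. Compound 4 `COc1ccc(NC(=O)Nc2nc(Sc3c[nH]c4ccccc34)cc(N3CCCC3)n2)cc1` differs from compound 2 at the outer phenyl ring: methoxy in place of chloro on an aromatic carbon. Among the measured compounds shown here, no measured step touches that ring, so nothing in the data argues for a large move in either direction; a step within the usual scatter is expected, namely a 1.4-fold higher number from compound 2 to compound 4 (0.15 log units; within the scatter). Compound 4 is therefore estimated at 9000 nM, with an expected range from 3500 nM to 25000 nM.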

Compound 4, half-maximal inhibitory concentration: 11800 nM
Estimate against measurement, compound 4: 1.3-fold (0.12 log units) below; measured number inside the range.
By their numbers in this assay, from the lowest: compounds 2, 4, 3 and 1 (each within the scatter of the next, the first and the last beyond it).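

The outer phenyl ring now has its first measured step: methoxy in place of chloro, para to a large group, gives a 1.8-fold higher number from compound 2 to compound 4 (0.27 log units; within the scatter) in this assay and so cannot be told apart from the normal spread of repeat measurements. The earlier step, on the pyrrolidin-1-yl group, lay beyond that spread, whereas this position shows no clear response to the swap. No outside evidence bears on this result.

From the compounds shown here alone, whether an amine or a carboxylic acid on this ring carbon would shift the number beyond the scatter stays open. So does whether the same swap behaves alike with piperidin-1-yl on the core.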